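The source may report more compounds than this note shows. Statements on the series, on what has been measured and on what is new or still open speak of the compounds shown alone.

Measured so far in a functional assay on MIA PaCa-2 cells (Homo sapiens) for cytotoxicity, read by MTT assay, with a stated time of 72 h; on this read-out lower numbers stand for stronger inhibition and higher numbers for weaker inhibition:

compound 1 `COC1=CC(=O)c2c(c(COc3cccnc3)c(C)n2C)C1=O`: 562 nM
compound 2 `COC1=CC(=O)c2c(c(COc3ccncc3)c(C)n2C)C1=O`: 2170 nM
compound 3 `COC1=CC(=O)c2c(COc3cccnc3)c(C)n(C)c2C1=O`: 1820 nM

Compounds 1 and 2 share one core; compound 3 carries a different core, and the difference between the two cores is not broken down here. Within the first core the change pyridin-4-yl in place of pyridin-3-yl on an oxygen on a saturated carbon gave a 3.9-fold higher number from compound 1 to compound 2 (0.59 log units; beyond the scatter). Compound 3 and compound 2 give numbers that lie within the scatter of each other, so nothing is said about their order; compound 3 stands beyond the scatter from compound 1.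

Compound 4 `COC1=CC(=O)c2c(COc3ccncc3)c(C)n(C)c2C1=O` is not yet measured. It differs from compound 3 by pyridin-4-yl in place of pyridin-3-yl on an oxygen on a saturated carbon, the same change as from compound 1 to compound 2, at the same place in the words given for each. Among the compounds with values here, only that one earlier instance is available, and it was on the other core, so the expectation for compound 4 in this assay rests on carrying it over: a step of about a 3.3-fold higher number from compound 3 to compound 4 (0.52 log units; beyond the scatter) is expected from compound 3, giving an estimated value for compound 4 of 6000 nM, with a plausible range from 2500 nM to 15000 nM.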

Compound 4, half-maximal inhibitory concentration: 3270 nM
Beside the measured number, compound 4's estimate is 1.8-fold (0.26 log units) above it, within the range that was stated.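

In this assay, pyridin-4-yl in place of pyridin-3-yl on the core of compound 3 gave a 1.8-fold higher number from compound 3 to compound 4 (0.25 log units; within the scatter), so no order can be stated for this pair. Set beside the earlier step, this result gives no sign that the effect of the change depends on the core: the same change on two cores in this assay, a 3.9-fold higher number (0.59 log units; beyond the scatter) from compound 1 to compound 2 and a 1.8-fold higher number (0.25 log units; within the scatter) from compound 3 to compound 4, 2.1-fold (0.33 log units) apart, within the scatter of two such steps. Within the data shown here, this is compatible with the change carrying over between the two cores, but it does not show that the step is the same size on both, since only one of the two steps stands clear of the scatter and a single pair per core gives little basis for a firm conclusion.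

As far as these compounds go, how a phenyl ring or a pyridin-2-yl group would compare at the same place on either core remains open. Also open, from the compounds shown here alone, is whether the oxygen link could give way to an amine, and how the two cores compare once such groups are present.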